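Amide substituent variation in a dilauroyl thioglycerol cysteine series

A few compounds are considered here, and "the series" means these few. Any claim that something is new, unique, unknown or untested is made for them only; others in the source may bear on it.

Measured so far:
compound 1, `CCCCCCCCCCCC(=O)OC[C@H](CSC[C@@H](N)C(=O)N[C@@H](C)CO)OC(=O)CCCCCCCCCCC`: 1560 nM
compound 2, `CCCCCCCCCCCC(=O)OC[C@H](CSC[C@@H](N)C(=O)N[C@H](C)CO)OC(=O)CCCCCCCCCCC`: 22200 nM
compound 3, `CCCCCCCCCCCC(=O)OC[C@H](CSC[C@@H](N)C(=O)NCCCS(=O)(=O)O)OC(=O)CCCCCCCCCCC`: 5560 nM

All three were read in an assay on HEK293 cells for agonist activity at Toll-like receptor 2 (Homo sapiens); a lower number here means that less compound is needed, a higher number that more compound is needed for the effect. Compound 3 sits in the middle of the three numbers: the step of a 3.6-fold higher number from compound 1 to compound 3 (0.55 log units; beyond the scatter) places it modestly behind compound 1, while the step of a 4.0-fold lower number from compound 2 to compound 3 (0.60 log units; beyond the scatter) places it modestly ahead of compound 2. The largest shift seen so far, a 14-fold higher number from compound 1 to compound 2 (1.15 log units; beyond the scatter), comes from the fact that compounds 1 and 2 differ only in the configuration as drawn, so the configuration at the amide-borne chain carbon weighs more than the exchange of the hydroxymethylethyl group for sulfopropyl.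

Compound 4, `CCCCCCCCCCCC(=O)OC[C@H](CSC[C@@H](N)C(=O)NC(C)CCc1ccccc1)OC(=O)CCCCCCCCCCC`, is the next case on the same amide nitrogen: 1-methyl-3-phenylpropyl in place of 3-sulfopropyl on an amide-type nitrogen. Among the measured compounds shown here, both measured exchanges at this nitrogen were modest, so a modest step is expected here too; no measured step speaks to a nonpolar aromatic substituent, so the direction is uncertain and a somewhat higher number is taken as the middle case. For compound 4 the estimate is 7000 nM, range 1500 nM to 35000 nM, corresponding to an expected step of a 1.3-fold higher number from compound 3 to compound 4 (0.10 log units; within the scatter).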

Compound 4, half-maximal effective concentration: 160 nM
For compound 4 the middle estimate is 44-fold (1.64 log units) above the measured one; the whole stated range lies above it.
By their numbers in this assay, from the lowest: compound 4; then compound 1; then compound 3; then compound 2.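

Read in this assay the amide nitrogen proves able to carry a group that gives a much lower number than either earlier substituent type. Placing 1-methyl-3-phenylpropyl there gives a 35-fold lower number from compound 3 to compound 4 (1.54 log units; beyond the scatter) against 3-sulfopropyl and a 140-fold lower number from compound 2 to compound 4 (2.14 log units; beyond the scatter) against the weaker 1-(hydroxymethyl)ethyl isomer. Even against the better isomer the step is a 9.8-fold lower number from compound 1 to compound 4 (0.99 log units; beyond the scatter) in the same direction, so the only substituent here with an aromatic ring, and with only carbon atoms, also gives the lowest number of the four.

From the compounds shown here alone, whether the phenyl ring or the branched chain carries this gain stays open, as would be read from 3-phenylpropyl, cyclohexyl-bearing or amine-bearing chains on this nitrogen. Compound 4 is also drawn without configuration at its chain carbon, and the size of a 14-fold higher number from compound 1 to compound 2 (1.15 log units; beyond the scatter) makes that gap matter: the fact that compounds 1 and 2 differ only in the configuration as drawn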